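A Second Chloro on Two Related Cores

The source may report more compounds than this note shows. Statements on the series, on what has been measured and on what is new or still open speak of the compounds shown alone.

Compound 1 `ClCc1ccc(Cn2cnc3c(Cl)ncnc32)cc1` and compound 3 `ClCc1ccc(Cn2cnc3c(Cl)nc(Cl)nc32)cc1` differ by a single change, (chloro in place of hydrogen on an aromatic carbon). In a functional assay on COLO 205 cells (Homo sapiens) for cytotoxicity, read by sulforhodamine B assay, with a stated time of 48 h (a higher number here means that more compound is tolerated, a lower number that less compound is tolerated), compound 1 gives > 100000 nM, which is a limit of the assay rather than a number. Compound 3 likewise gives > 100000 nM, again a limit. The step that the two limits leave unreadable from compound 1 to compound 3 therefore cannot be sized, as the limit of > 100000 nM in this assay, at which 3 of the 3 values shown sit, shows. Compound 2 `ClCc1ccccc1Cn1cnc2ncnc(Cl)c21` holds the same atoms as compound 1 joined differently; the difference between the two cores is not broken down here. In this assay compound 2 gives > 100000 nM, also a limit. Compound 4 `ClCc1ccccc1Cn1cnc2nc(Cl)nc(Cl)c21` carries the same change relative to compound 2, (chloro in place of hydrogen on an aromatic carbon), at a place described in identical words. Compound 3 stayed at a limit, > 100000 nM, after this change. On that ground compound 4 is expected to give 100000 nM, an expected step of a number no higher from compound 2 to compound 4 (the limit leaves the size open), most likely reported once more as a limit.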

Compound 4, concentration lethal to 50% of the cells: > 100000 nM
Compound 4: no number, only a limit (the forecaster's own chance of this, stated with the estimate: 85%); the middle value sits exactly at the limit.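

No step can be read between compound 2 and compound 4, since both values are limits of the assay and not numbers: the limit of > 100000 nM in this assay, at which 4 of the 4 values shown sit.

The compounds shown leave open how much compound each of the four tolerates in this assay and whether the added chloro changes that.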